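A few compounds are considered here, and "the series" means these few. Any claim that something is new, unique, unknown or untested is made for them only; others in the source may bear on it.

Compound 1 `C=CC(=O)Nc1cccc(Nc2nc(N/N=C/c3ccccc3F)ncc2Cl)c1`: 3500 nM
Compound 2 `CN(C)C/C=C/C(=O)Nc1cccc(Nc2nc(N/N=C/c3ccccc3F)ncc2Cl)c1`: 3660 nM

Both compounds were measured in an ADME assay on HT-29 cells (Homo sapiens) for inhibition, read by MTT assay, with a stated time of 72 h; on this read-out lower numbers stand for stronger inhibition and higher numbers for weaker inhibition. Among the compounds with values here, the only step between measured compounds, a 1.0-fold higher number from compound 1 to compound 2 (0.02 log units; within the scatter), changes the group on the carbonyl carbon and not the aromatic ring, and it falls within the scatter. On the two numbers shown, compound 2 and compound 1 sit together; their difference is within the scatter, so neither can be placed above the other.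

Compound 3 `CN(C)C/C=C/C(=O)Nc1cccc(Nc2nc(N/N=C/c3ccc(F)cc3F)ncc2Cl)c1` is the next compound. It differs from compound 2 in one place: fluoro in place of hydrogen on an aromatic carbon, which, read one bond further out, is 2-fluorophenyl to 2,4-difluorophenyl. Within the data shown here, no measured step touches this ring, so the data give no direct guide to this change. Among the measured compounds shown here, the one step available, a 1.0-fold higher number from compound 1 to compound 2 (0.02 log units; within the scatter), concerns a different part of the molecule and is itself within the scatter. With nothing pointing either way, the expected step is a 1.0-fold lower number from compound 2 to compound 3 (0.02 log units; within the scatter), that is, no change beyond the scatter. The estimate for compound 3 in this assay is therefore 3500 nM, with a range from 1500 nM to 8500 nM.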

Compound 3, half-maximal inhibitory concentration: 2920 nM
Estimate against measurement, compound 3: 1.2-fold (0.08 log units) above, and the stated range covers the measured number.
By their numbers in this assay, from the lowest: compounds 3, 1 and 2 (each within the scatter of the next).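

Within the data shown here, with compound 3, a measured step reaches the fluorophenyl ring for the first time, as the earlier step changed only the group on the carbonyl carbon. In this assay, going from 2-fluorophenyl to 2,4-difluorophenyl gives a 1.3-fold lower number from compound 2 to compound 3 (0.10 log units; within the scatter), so a fluoro group placed meta to a fluoro group and para to a large group yields a number that cannot be told apart from that of its parent. This is a single comparison on one background and in one assay, and nothing available bears on why the read-out comes out this way.

The compounds shown leave open whether a different group at this place, such as methoxy, trifluoromethyl or an amine, would give a step beyond the scatter, since fluoro is the only group tried there so far. They also leave open whether the same fluoro change on compound 1, which carries vinyl in place of 3-(dimethylamino)prop-1-en-1-yl on the carbonyl carbon, would give a similar result.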